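The source may report more compounds than this note shows. Statements on the series, on what has been measured and on what is new or still open speak of the compounds shown alone.

Measured compounds in a functional assay on CHO.K1 cells for antagonist activity at prostaglandin D2 receptor 2 (Homo sapiens), read by GTPgammaS binding, with a stated time of 1 h; on this read-out higher numbers stand for weaker inhibition and lower numbers for stronger inhibition:
compound 1 `Cc1c(Cc2ccccc2S(=O)(=O)c2cccc(Cl)c2)c2c(n1CC(=O)O)CCNC2=O` — 4 nM
compound 2 `COc1ccc(S(=O)(=O)c2ccc(F)cc2)c(Cc2c3c(n(CC(=O)O)c2C)CCNC3=O)c1` — 7.1 nM
compound 3 `Cc1c(Cc2ccc(S(=O)(=O)Cc3ccccc3)cc2)c2c(n1CC(=O)O)CCNC2=O` — 3 nM

All three carry the same core with an acetic acid on the ring nitrogen and a benzyl group bearing a sulfonyl substituent. The number for compound 1 lies between those of compound 3 and compound 2, and both gaps are within the scatter, so the three compounds cannot be told apart on this assay.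

Compound 4 `Cc1c(Cc2ccccc2-c2cccc3ccccc23)c2c(n1CC(=O)O)CCNC2=O` has not been measured. It differs from compound 1 in one place: naphthalen-1-yl in place of (3-chlorophenyl)sulfonyl on an aromatic carbon. Going by the values given here, no measured pair in the set isolates this kind of exchange, so there is no step to lean on; the only guide is that every measured member keeps a sulfonyl and all sit close together.

With the sulfonyl gone and a second aromatic ring entering, some loss is expected, but a modest one, since the rest of compound 1 is retained; the expected step of a 3.8-fold higher number from compound 1 to compound 4 (0.57 log units; beyond the scatter) is toward a higher number, though it may fall within the scatter. Compound 4 is estimated at 15 nM in this assay, with a range from 3 nM to 80 nM.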

Compound 4, half-maximal inhibitory concentration: 480 nM
For compound 4 the middle estimate is 32-fold (1.51 log units) below the measured one; measured number above the stated range.
By their numbers in this assay, from the lowest: compounds 3, 1 and 2 (each within the scatter of the next, the first and the last beyond it); then compound 4.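

In this assay, naphthalen-1-yl in place of (3-chlorophenyl)sulfonyl on an aromatic carbon, ortho to a large group, gives a 120-fold higher number from compound 1 to compound 4 (2.08 log units; beyond the scatter) and is a large loss, so this position does not accept every aromatic substituent of 10 heavy atoms. Going by these compounds alone, the earlier compounds all keep a sulfonyl and gave no view of what happens when it leaves; this step is the first reading of that change, and it shows that matching the heavy-atom count does not preserve inhibition here. The exchange removes 2 hydrogen-bond acceptors and 2 double bonds outside aromatic rings and adds a second six-membered aromatic ring, but no measurement on hand says which of these differences accounts for the loss.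

The compounds shown leave open whether the loss follows from removing the sulfonyl or from bringing in the naphthalen-1-yl, since both happen in the one step. A naphthalen-1-ylsulfonyl group at this place would separate the two, and a 3-chlorophenyl group joined directly to the aromatic carbon would test the sulfonyl link on its own.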